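The source may hold more compounds than are shown below. What is called first, only, known or untested is meant among the compounds shown, and "the series" means these compounds.

Compound 1 `Cc1ccc(-c2cs/c(=N/NC(=O)CSc3nnnn3-c3ccccc3)n2-c2ccccc2)cc1`: 38.8%
Compound 2 `O=C(CSc1nnnn1-c1ccccc1)N/N=c1/scc(-c2ccccc2)n1-c1ccccc1`: 42.5%

Among the compounds with values here, in a functional assay on C6 cells (Rattus norvegicus) for cytotoxicity, read by MTT assay, with a stated time of 24 h, tested at 25 ug/mL (a higher number here means a weaker effect of the compound at the concentration tested, a lower number a stronger effect), compound 2 and compound 1 give numbers within the scatter of each other, and the only measured step, a number 3.7 percentage points higher from compound 1 to compound 2 (within the scatter), is small. Compound 3 `O=C(CSc1nnnn1-c1ccccc1)N/N=c1/scc(-c2ccc(Cl)cc2)n1-c1ccccc1` carries the change (chloro in place of hydrogen on an aromatic carbon). Within the data shown here, the one step that bears on it, also an exchange of a single group on an aromatic carbon, stayed within the scatter, so no step beyond the scatter is expected in this assay here either. Compound 3 is therefore estimated at 42%, with a range from 28% to 56%, an expected step of a number 0.5 percentage points lower from compound 2 to compound 3 (within the scatter).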

Compound 3, a percentage reported as activity, at one concentration (the size of the read-out at that concentration, not a potency): 62.3%
Compound 3: the middle estimate sits 20.3 percentage points below what was measured; the whole stated range lies below it.
By their numbers in this assay, from the lowest: compounds 1 and 2 (each within the scatter of the next); then compound 3.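

In this assay, the place on the six-membered aromatic ring of carbon only, para to a large group, proves sensitive to the group it carries: going from phenyl to 4-chlorophenyl gives a number 19.8 percentage points higher from compound 2 to compound 3 (beyond the scatter) and so a weaker effect at the concentration tested, although hydrogen and methyl there lay within the scatter of each other. Chloro also stands apart from methyl, with a number 23.5 percentage points higher from compound 1 to compound 3 (beyond the scatter) in the same direction. No measurement shown offers an explanation for this.

On these data alone, whether fluoro, methoxy or an amine at this place would behave like chloro or like methyl remains open. So does whether the chloro step would persist with the other parts of the core changed.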